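This account rests on a few compounds, and the source may have more. Where it says the series, first, only, none or still open, it means among the compounds named here.

Measured so far in a functional assay on A549 cells (Homo sapiens) for antiproliferative activity, read by CCK-8 assay, with a stated time of 48 h; a higher number here means a weaker inhibitor, a lower number a stronger inhibitor: compound 1 `O=c1c2ccccc2[se]n1-c1nc(SCc2ccccc2)n[nH]1` gives a value that is a limit of the assay, > 50000 nM. Compound 2 `Cc1ccccc1CSc1n[nH]c(-n2[se]c3ccccc3c2=O)n1` gives 9720 nM. Compound 3 `CC(C)Sc1n[nH]c(-n2[se]c3ccccc3c2=O)n1` gives 36600 nM.

Compound 3 holds the highest of the two numbers that are numbers at all; its nearest neighbour is compound 2, and the step of a 3.8-fold higher number from compound 2 to compound 3 (0.58 log units; beyond the scatter) lies beyond the scatter. The value of compound 1 is only a limit (the limit of > 50000 nM in this assay, at which 1 of the 3 values shown sits), and the step of an at least 1.3-fold lower number from compound 1 to compound 3 (0.13 log units; that floor lies within the scatter) has a floor that sits within the scatter.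

Compound 4 `CCCCCSc1n[nH]c(-n2[se]c3ccccc3c2=O)n1` differs from compound 3 by pentyl in place of isopropyl on a sulfur. The two measured steps that bear on this change are the ones on the same sulfur: the step of an at least 1.3-fold lower number from compound 1 to compound 3 (0.13 log units; that floor lies within the scatter) gives no reading beyond the scatter, while the step of a 3.8-fold higher number from compound 2 to compound 3 (0.58 log units; beyond the scatter) shows a modest rise on going to the isopropyl group. Neither step compares two open chains, so the direction for pentyl is read only loosely from them. Compound 4 is therefore expected to land near compound 3 or somewhat lower, with an expected step of a 1.7-fold lower number from compound 3 to compound 4 (0.22 log units; within the scatter). The estimate for compound 4 in this assay is 22000 nM, with a range from 7000 nM to 60000 nM.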

Compound 4, half-maximal inhibitory concentration: 21100 nM
Estimate against measurement, compound 4: 1.0-fold (0.02 log units) above; measured number inside the range.
By their numbers in this assay, from the lowest: compound 2; then compounds 4 and 3 (each within the scatter of the next). At a limit, above all of these: compound 1.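

Pentyl in place of isopropyl on a sulfur is the first comparison here between two open chains, and it gives a 1.7-fold lower number from compound 3 to compound 4 (0.24 log units; within the scatter), so in this assay these two chains cannot be told apart. On the saturated chain carbon bound to a sulfur, butyl in place of 2-methylphenyl gives a 2.2-fold higher number from compound 2 to compound 4 (0.34 log units; beyond the scatter), while butyl in place of phenyl gives an at least 2.3-fold lower number from compound 1 to compound 4 (0.37 log units; beyond the scatter), which places the pentyl compound between the 2-methylbenzyl compound and the unsubstituted benzyl compound. The last of these steps is only a floor, since the value of compound 1 is a limit of the assay and not a number: the limit of > 50000 nM in this assay, at which 1 of the 4 values shown sits.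

As far as these compounds go, whether the open-chain reading holds for a longer chain such as decyl, or for a chain ending in an amine or a carboxylic acid, remains open. It is also open whether a methoxy group or a chlorine on the same aromatic carbon would give a step like the one that methyl gives, and the compounds shown offer no reason for any of these numbers.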